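Extending the chain on the aromatic nitrogen of compound 2

This account rests on a few compounds, and the source may have more. Where it says the series, first, only, none or still open, it means among the compounds named here.

Of the compounds shown here, two share the core and have been measured. Compound 1 `COc1ccc(C(C)=O)cc1CSc1nc2cc(NC(=O)C3CC3)ccc2n1C(C)C` is one of them; in an assay on isolated protein for inhibition of Gonadotropin-releasing hormone receptor (Homo sapiens) (a lower number here means a stronger inhibitor, a higher number a weaker inhibitor), compound 1 gives 260 nM. The other, compound 2 `CCn1c(SCc2cc([N+](=O)[O-])ccc2OC)nc2cc(NC(=O)NC(C)(C)C)ccc21`, gives in this assay a value of 42 nM, the lower of the two numbers, and the gap to compound 1 lies beyond the usual scatter. The next step leads from compound 2 to compound 3 `CCCCn1c(SCc2cc([N+](=O)[O-])ccc2OC)nc2cc(NC(=O)NC(C)(C)C)ccc21`, which has not yet been measured. The change is ethyl in place of hydrogen on a saturated chain carbon, two bonds along the chain from an aromatic nitrogen, so that the chain on the aromatic nitrogen grows from ethyl to butyl while the rest of the structure stays as in compound 2. Among the compounds with values here, no measured pair shows this kind of change, so there is no step to lean on. The expectation is that compound 3 stays near compound 2, with a step of a 1.2-fold higher number from compound 2 to compound 3 (0.08 log units; within the scatter) that is not expected to go beyond the scatter in either direction. Compound 3 is therefore expected to give in this assay about 50 nM, within a range from 15 nM to 170 nM.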

Compound 3, half-maximal inhibitory concentration: 23 nM
Compound 3: the middle estimate sits 2.2-fold (0.34 log units) above what was measured; low and high end bracket the measured number.
By their numbers in this assay, from the lowest: compounds 3 and 2 (each within the scatter of the next); then compound 1.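

In this assay, within the data shown here, the growth of the chain on the aromatic nitrogen from ethyl to butyl gives a 1.8-fold lower number from compound 2 to compound 3 (0.26 log units; within the scatter) and is the first step that can be read at this position, since the earlier compounds offered no pair differing in one place. With the rest of compound 2 held fixed, ethyl in place of hydrogen on this saturated chain carbon therefore leaves the number within the usual scatter, so this one pair shows that the position carries the two added carbons without a measurable loss or gain in binding inhibition. Nothing at hand explains why the step is this small, and a single pair sets no trend along the chain.

The compounds shown leave open how far this tolerance extends, for instance whether a hexyl chain on the same nitrogen would still stay within the scatter of compound 2 or would move beyond it. They also leave open whether a chain ending in an amine or a carboxylic acid would be accepted here as the plain butyl chain of compound 3 is.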